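The compounds below may be only part of what the source reports. "The series", "measured", "known", "first", "only" and "open" are said of these compounds alone.

Working notes on the series. In an assay on HEK293 cells for agonist activity at transient receptor potential cation channel subfamily M member 8 (Homo sapiens), read by fluorescence and calcium flux, with a stated time of 15 min (on this read-out lower numbers stand for an effect already at smaller amounts and higher numbers for an effect only at larger amounts of compound), compound 1 `CCc1ccc(OCC(=O)N(CC)Cc2cccs2)cc1` gives 67 nM, and compound 2 `CCN(Cc1cccs1)C(=O)COc1ccc(C)cc1O` gives 8 nM; the two values show compound 2 reaching its effect at the smaller amount. Compound 3 `CCN(Cc1cn[nH]c1)C(=O)COc1ccc(C)cc1` is reported in this assay only as "active" (no number reported), with no number beside it, so compound 3 cannot be placed against compound 1 or compound 2 on the scale. Compound 4 `CCN(Cc1cccs1)C(=O)COc1ccc(C)cc1` differs from compound 3 in one place: thiophen-2-yl in place of 1H-pyrazol-4-yl on a saturated chain carbon bound to an amide-type nitrogen. Among the compounds with values here, no step between measured compounds covers this change, so the size of the step from compound 3 to compound 4 in this assay remains open; compound 3 carries no number, so no direction can be stated from it either. The expectation for compound 4 rests instead on compound 1 with 67 nM and compound 2 with 8 nM, both of which share the thiophen-2-yl group with compound 4 and differ from it elsewhere in the structure. On that basis compound 4 is expected to give about 30 nM in this assay, with a range from 8 nM to 120 nM.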

Compound 4, half-maximal effective concentration: 8 nM
Estimate against measurement, compound 4: 3.8-fold (0.57 log units) above; low and high end bracket the measured number.
By their numbers in this assay, from the lowest: compounds 2 and 4 (each within the scatter of the next); then compound 1.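

In this assay, hydrogen in place of methyl on a saturated chain carbon bound to an aromatic carbon gives an 8.4-fold lower number from compound 1 to compound 4 (0.92 log units; beyond the scatter) and marks this place as one where a single added carbon registers beyond the scatter, which the earlier values alone could not isolate. Hydrogen in place of hydroxy on an aromatic carbon gives no change at the digits printed from compound 2 to compound 4 (within the scatter) and shows that, with thiophen-2-yl held constant, the hydroxy group is not required for a number at this level. Compound 3 carries no number, so the change from (1H-pyrazol-4-yl)methyl to (thiophen-2-yl)methyl cannot be read as a step, and compound 4 adds only a measured thiophen-2-yl reference point for it.

The compounds shown leave open how a propyl chain, a longer chain, or an amine or carboxylic acid would read on that saturated chain carbon. They also leave open how methoxy or fluorine would read in place of hydroxy on the aromatic carbon, and what number a 1H-pyrazol-4-yl compound would give. No measurement at hand accounts for the size of either step.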